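The source may hold more compounds than are shown below. What is called first, only, known or untested is meant among the compounds shown, and "the series" means these compounds.

Compound 1 `c1cncc(-c2ccccc2OCC2=NCCN2)c1`: 1290 nM
Compound 2 `Cc1ccnc(-c2ccccc2OCC2=NCCN2)c1`: 2450 nM

In an assay on cell membranes for binding affinity to Alpha-1B adrenergic receptor (Homo sapiens) (a lower number here means a stronger inhibitor, a higher number a weaker inhibitor), compound 1 gives 1290 nM and compound 2 gives 2450 nM. Compound 1 has the smaller of the two numbers, but the gap between them lies within the scatter, so the two cannot be told apart. Compound 3 `c1c[nH]c(-c2ccccc2OCC2=NCCN2)c1` has not yet been measured in this assay. It differs from compound 1 by 1H-pyrrol-2-yl in place of pyridin-3-yl on an aromatic carbon. For the measured compounds named here, no measured pair shows this change, so its effect is unknown. The expected step is a 1.3-fold lower number from compound 1 to compound 3 (0.11 log units; within the scatter), small and not clearly beyond the scatter in either direction. For compound 3 the estimated value in this assay is 1000 nM, with a range from 300 nM to 3500 nM.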

Compound 3, half-maximal inhibitory concentration: 269 nM
Estimate against measurement, compound 3: 3.7-fold (0.57 log units) above; measured number outside the range, below it.
By their numbers in this assay, from the lowest: compound 3; then compounds 1 and 2 (each within the scatter of the next).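

In this assay there is a 4.8-fold lower number from compound 1 to compound 3 (0.68 log units; beyond the scatter) with 1H-pyrrol-2-yl in place of pyridin-3-yl, a step beyond the scatter. On this aromatic carbon, ortho to a group of 7 heavy atoms, the number therefore responds to which aromatic ring is attached, and the five-membered ring with its hydrogen-bond donor carries the lower number. Nothing measured here accounts for the step.

The compounds shown leave open whether furan-2-yl, thiophen-2-yl or a pyrrole with methyl on its nitrogen would give a similar step. They also cannot separate the change in ring size from the gain of the hydrogen-bond donor.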